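Trimming the branched chain of compound 3

A few compounds are considered here, and "the series" means these few. Any claim that something is new, unique, unknown or untested is made for them only; others in the source may bear on it.

Measured in an in vitro ADME assay on microsomes from liver (Homo sapiens) for metabolic stability, tested at 5 uM; on this read-out higher numbers stand for a longer-lived compound and lower numbers for a shorter-lived compound:
compound 1 `CC(C)CCn1nc(-c2cccs2)c(O)c(C2=NS(=O)(=O)c3cc(S(C)(=O)=O)ccc3N2)c1=O`: 0.0933 h
compound 2 `CC(C)CCn1nc(CCC(F)(F)F)c(O)c(C2=NS(=O)(=O)c3cc(NS(C)(=O)=O)ccc3N2)c1=O`: 0.517 h
compound 3 `CCC(C)(C)Cn1nc(-c2cccs2)c(O)c(C2=NS(=O)(=O)c3cc(NS(C)(=O)=O)ccc3N2)c1=O`: > 1 h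

Compound 3 gives > 1 h, which is a limit and not a number.

Compound 4 `CC(C)Cn1nc(-c2cccs2)c(O)c(C2=NS(=O)(=O)c3cc(NS(C)(=O)=O)ccc3N2)c1=O` differs from it by one change: hydrogen in place of ethyl on a saturated chain carbon bound to three saturated chain carbons, so that 2,2-dimethylbutyl becomes isobutyl. Among the measured compounds shown here, no measured pair isolates this change, so any expectation in this assay is loose. Compound 2 at 0.517 h is the closest measured number. The expected step of an at least 1.2-fold lower number from compound 3 to compound 4 (0.09 log units; that floor lies within the scatter) is a modest shortening of half-life, possibly none beyond the scatter. Compound 4 is estimated at 0.8 h, with an expected range of 0.3 h to 2 h.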

Compound 4, half-life: > 1 h
Compound 4 ended at the assay's limit; the forecaster's own chance of this, stated with the estimate: 35%; at least 1.2-fold (0.09 log units) between middle value and limit.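

Compound 3 and compound 4 both stand at a limit rather than at a number, so no step between them can be read: the limit of > 1 h in this assay, at which 2 of the 4 values shown sit.

The compounds shown leave open whether going from 2,2-dimethylbutyl to isobutyl changes half-life at all.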